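Methylsulfanyl in Place of Methoxycarbonyl: Cytotoxicity Outlook

The compounds below may be only part of what the source reports. "The series", "measured", "known", "first", "only" and "open" are said of these compounds alone.

Compound 1 `COc1ccc(NC(=O)Nc2cc(C)nc3ccccc23)cc1`: > 25000 nM
Compound 2 `Cc1ccc(NC(=O)Nc2cc(C)nc3ccccc23)cc1`: > 25000 nM
Compound 3 `COC(=O)c1ccc(NC(=O)Nc2cc(C)nc3ccccc23)cc1`: 21000 nM

Of the compounds shown here, three sharing one core have been tested in an ADME assay on BJ cells (Homo sapiens) for cytotoxicity, with a stated time of 72 h; a higher number here means that more compound is needed for the effect, a lower number that less compound is needed. Compound 1 reached only the limit of > 25000 nM. Compound 2 likewise stopped at the limit of > 25000 nM. Compound 3 alone gave a number, 21000 nM, so it stands as the only read point among the three. The measured steps toward it are an at least 1.1-fold lower number from compound 1 to compound 3 (0.07 log units; that floor lies within the scatter) and an at least 1.1-fold lower number from compound 2 to compound 3 (0.07 log units; that floor lies within the scatter), each within the scatter, in line with the limit of > 25000 nM in this assay, at which 2 of the 3 values shown sit.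

Compound 4 `CSc1ccc(NC(=O)Nc2cc(C)nc3ccccc23)cc1` awaits measurement in this assay. (methylsulfanyl in place of methoxycarbonyl on an aromatic carbon). Among the compounds with values here, no measured step touches methylsulfanyl, and the two known steps onto the same position were both within the scatter. Compound 4 is therefore expected to move little, a 1.2-fold higher number from compound 3 to compound 4 (0.08 log units; within the scatter). The value of compound 4 in this assay is estimated at 25000 nM, somewhere between 12000 nM and 60000 nM.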

Compound 4, half-maximal effective concentration in the BJ assay: > 25000 nM
Compound 4 was reported as a limit; the forecaster's own chance of this, stated with the estimate: 55%; the middle value sits exactly at the limit.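

In the BJ assay the exchange of methoxycarbonyl for methylsulfanyl gives an at least 1.1-fold higher number from compound 3 to compound 4 (0.07 log units; that floor lies within the scatter), so this change shows no readable effect. Compound 4 ends at a limit of the assay, as compound 1 and compound 2 do, and the steps among these three cannot be read: the limit of > 25000 nM in the BJ assay, at which 3 of the 4 values shown sit. In a physicochemical assay for solubility, at pH 7.4 (a higher number here means a more soluble compound, a lower number a less soluble compound), compound 3 gives 1200 nM and compound 4 gives 1300 nM, which is a 1.1-fold higher number from compound 3 to compound 4 (0.03 log units; within the scatter).

Going by these compounds, with only compound 3 giving a number in the BJ assay, how far this position can shift the result stays open. So does what a carboxylic acid or an amine would do there.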